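A few compounds are considered here, and "the series" means these few. Any claim that something is new, unique, unknown or untested is made for them only; others in the source may bear on it.

Measured so far in a functional assay (Cardiac muscle cell, Rattus norvegicus, strain Sprague-Dawley) for inhibition, read by LDH release, with a stated time of 6 h (on this read-out higher numbers stand for an effect only at larger amounts of compound and lower numbers for an effect already at smaller amounts), are these compounds:
- compound 1 `COC(=O)c1oc2ccccc2c1NC(=O)CSc1ccc(Br)cc1` with 778 nM
- compound 2 `COC(=O)c1oc2ccccc2c1NC(=O)CSc1ccc(OC)cc1` with 752 nM

Going by the values given here, compound 2 cannot be separated from compound 1, the only other measured compound, since their two values lie within the usual scatter of each other.

Compound 3 `COC(=O)c1oc2ccccc2c1NC(=O)CSc1ccc([N+](=O)[O-])cc1` has not yet been measured. It keeps the core of compound 2 but carries nitro in place of methoxy on an aromatic carbon, para to a large group (nitro in place of methoxy on an aromatic carbon).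

Among the compounds with values here, only one measured step bears on this change. At the same aromatic carbon, methoxy in place of bromo gave a 1.0-fold lower number from compound 1 to compound 2 (0.01 log units; within the scatter) and stayed within the scatter. Within the data shown here, that single step covers bromo and methoxy only, and no measurement yet shows how nitro behaves there. Taking compound 2 with 752 nM as the starting point, no step beyond the scatter is expected in this assay for now, though with a wide margin. The expected size is a 1.0-fold lower number from compound 2 to compound 3 (0.00 log units; within the scatter) and no more than that. For compound 3 the estimated value is 750 nM with an expected range from 300 nM to 1900 nM in this read-out.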

Compound 3, half-maximal effective concentration: 532 nM
Compound 3: the middle estimate sits 1.4-fold (0.15 log units) above what was measured; the range from low to high includes it.
By their numbers in this assay, from the lowest: compounds 3, 2 and 1 (each within the scatter of the next).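

At this aromatic carbon, para to a large group, nitro now joins bromo and methoxy: in this assay, nitro in place of methoxy gives a 1.4-fold lower number from compound 2 to compound 3 (0.15 log units; within the scatter), and nitro in place of bromo gives a 1.5-fold lower number from compound 1 to compound 3 (0.17 log units; within the scatter). The earlier step covered only bromo and methoxy, whereas these steps show that the exchange of methoxy, with 2 heavy atoms and 1 hydrogen-bond acceptor, for nitro, with 3 heavy atoms and 2 hydrogen-bond acceptors, also leaves compound 3 within the scatter of compound 2, so all three groups remain indistinguishable in this read-out. No supporting measurement is available to explain this lack of separation.

From the compounds shown here alone, it remains open whether an amine, a carboxylic acid or a longer chain at this same carbon would produce a step beyond the scatter, or whether these three compounds simply share a level that other groups would also reach. All three compounds keep the same core and the same chain leading to the aromatic ring. They say nothing about how changes in those parts would affect the number.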